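This account rests on a few compounds, and the source may have more. Where it says the series, first, only, none or still open, it means among the compounds named here.

Measured compounds in a functional assay on IMR-32 cells (Homo sapiens) for inhibition, read by sulforhodamine B assay, with a stated time of 48 h, tested at 100 uM; a lower number here means less inhibition of growth, a higher number more inhibition of growth at the concentration tested:
- compound 1, `O=c1c(C2N=C(c3ccccc3)SS2)coc2ccc(F)cc12`, gives 75%
- compound 2, `O=c1c(C2N=C(c3ccccc3)SS2)coc2ccccc12`, gives 82%
- compound 3, `O=c1c(C(=S)Nc2ccccc2)coc2ccccc12`, gives 53%

Compound 2 and compound 1 share one core and differ in one place: fluoro in place of hydrogen on an aromatic carbon. In this assay this change gives a number 7 percentage points lower from compound 2 to compound 1 (within the scatter), so the two numbers cannot be told apart.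

Compound 3 carries a different core; the difference between the two cores is not broken down here. Its number is the lowest of the three: compound 1 lies beyond the scatter above it, and compound 2 further still.

Compound 4, `O=c1c(C(=S)Nc2ccccc2)coc2ccc(F)cc12`, is not yet measured in this assay. It stands to compound 3 as compound 1 stands to compound 2: the change is fluoro in place of hydrogen on an aromatic carbon, the same change as in the measured pair, and it occurs two times among the compounds shown. The expectation rests on that single measured instance, which left the number within the scatter. The expected step is a number 4 percentage points lower from compound 3 to compound 4 (within the scatter), small because a number 7 percentage points lower from compound 2 to compound 1 (within the scatter) was found for the same change on the other core. Whether the change behaves alike on the core of compound 3 is not shown by any measured pair, so the range is kept wide. Compound 4 is expected at 49%, in a range from 33% to 65%.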

Compound 4, percent growth inhibition at one concentration: 59%
Compound 4: middle estimate off by 10 percentage points, on the low side, and the stated range covers the measured number.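

In this assay, fluoro in place of hydrogen on an aromatic carbon now has a second reading on a second core, with a number 6 percentage points higher from compound 3 to compound 4 (within the scatter). Set beside the earlier reading, the two steps cannot be told apart: the same change on two cores in this assay, a number 7 percentage points lower (within the scatter) from compound 2 to compound 1 and a number 6 percentage points higher (within the scatter) from compound 3 to compound 4, 13 percentage points apart, within the scatter of two such steps

On the two cores shown, the change can therefore be carried across with the working expectation of no readable shift in this assay, and the opposite directions of the two steps carry no meaning; this does not show that the change is without effect in general, since two pairs read at a single concentration say nothing about other cores, other assays or a full concentration response.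

The compounds shown leave open whether any other group on that aromatic carbon, such as chloro, methoxy, an amine or a carboxylic acid, would move the number beyond the scatter on either core. They also leave open what fluoro would do on another carbon of the same ring, and whether a group that does shift the number on one core would shift it in the same way on the other.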